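Chalcone ureas and thioureas: methoxy to chloro on the aryl

The source may hold more compounds than are shown below. What is called first, only, known or untested is meant among the compounds shown, and "the series" means these compounds.

Three compounds carry numbers in a functional assay on the whole organism (Abdomen, strain Swiss) with Mus musculus as the target, with a stated time of 30 min; a higher number here means that more compound is needed for the effect, a lower number that less compound is needed. Compound 1 `O=C(/C=C/c1ccc(Cl)c(Cl)c1)c1ccc(NC(=S)Nc2ccc(Cl)cc2)cc1` gives 6.15 umol/kg, compound 3 `Cc1ccc(/C=C/C(=O)c2ccc(NC(=S)Nc3ccc(Cl)cc3)cc2)cc1` gives 13.1 umol/kg, and compound 2 `COc1ccc(/C=C/C(=O)c2ccc(NC(=O)Nc3ccc(Cl)cc3)cc2)cc1` gives 31.1 umol/kg. Compound 2 thus stands highest of the three; compound 3 lies nearest and compound 1 furthest from it, both beyond the scatter, and since compound 2 differs from each of them in more than one place, only the bare values speak here.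

Compound 4 `O=C(Nc1ccc(Cl)cc1)Nc1ccc(C(=O)/C=C/c2ccc(Cl)cc2)cc1` is not yet measured. Against compound 2 the change is chloro in place of methoxy on an aromatic carbon. Among the compounds with values here, no measured step covers this exchange. Within the data shown here, the one single-place step, a 2.1-fold higher number from compound 1 to compound 3 (0.33 log units; beyond the scatter), concerns a different pair of aryl groups and bears only loosely on it; it shows that the aryl substituent does move this assay by a modest amount, and the halogen-bearing compound 1 gives the lowest value in the set.

On that basis a modest downward step is expected, a 1.6-fold lower number from compound 2 to compound 4 (0.19 log units; within the scatter), and compound 4 is estimated at 20 umol/kg, within 9 umol/kg to 45 umol/kg.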

Compound 4, dose for 50% inhibition: 45.4 umol/kg
For compound 4 the middle estimate is 2.3-fold (0.36 log units) below the measured one, outside the stated range (above it).
By their numbers in this assay, from the lowest: compound 1; then compound 3; then compounds 2 and 4 (each within the scatter of the next).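

Read as a single-place step, the exchange of 4-methoxyphenyl for 4-chlorophenyl gives a 1.5-fold higher number from compound 2 to compound 4 (0.16 log units; within the scatter) in this assay, so on this aromatic carbon, para to a large group, the two substituents cannot be told apart on the urea compounds. Within the data shown here, this is the first reading at this position with only the substituent changed; the earlier step concerned a different pair of aryl groups on a thiourea. Nothing available accounts for this result or gives a measured property of either group at this place.

From the compounds shown here alone, it remains open whether the same exchange reads alike with the thiourea link in place of the urea. Also open, going by these compounds, is whether a dimethylamino group or a carboxylic acid at this place would stay within the scatter of compound 2 or move beyond it.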